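Swapping the benzyl substituent: nitro to methoxy

A few compounds are considered here, and "the series" means these few. Any claim that something is new, unique, unknown or untested is made for them only; others in the source may bear on it.

Compound 1, `O=c1ccoc2cc(OCc3cn(Cc4cccc(Cl)c4)nn3)ccc12`, in a functional assay on QGY7701 cells (Homo sapiens) for cytotoxicity, read by MTT assay, with a stated time of 48 h (on this read-out lower numbers stand for stronger inhibition and higher numbers for weaker inhibition), gives 28400 nM.
Compound 2, `O=c1ccoc2cc(OCc3cn(Cc4cccc([N+](=O)[O-])c4)nn3)ccc12`, in this assay gives 14100 nM.

Among the compounds with values here, compound 2 has the lowest of the two numbers so far, though the only measured step, a 2.0-fold lower number from compound 1 to compound 2 (0.30 log units; within the scatter), stays within the scatter, so the two compounds cannot be ranked. Compound 3, `COc1ccc(Cn2cc(COc3ccc4c(=O)ccoc4c3)nn2)cc1`, differs from compound 2 in one place: 4-methoxyphenyl in place of 3-nitrophenyl on a saturated chain carbon bound to an aromatic nitrogen. Within the data shown here, the one step that bears on this, a 2.0-fold lower number from compound 1 to compound 2 (0.30 log units; within the scatter), also replaced the group on this same aromatic ring and produced nothing beyond the scatter, so no step beyond the scatter is expected in this assay here either. Compound 3 is therefore estimated at 20000 nM, with a range from 7000 nM to 60000 nM. The expected step is then a 1.4-fold higher number from compound 2 to compound 3 (0.15 log units; within the scatter).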

Compound 3, half-maximal inhibitory concentration: 56600 nM
Beside the measured number, compound 3's estimate is 2.8-fold (0.45 log units) below it; the range from low to high includes it.
By their numbers in this assay, from the lowest: compounds 2, 1 and 3 (each within the scatter of the next, the first and the last beyond it).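

In this assay, the group on this saturated chain carbon can matter: a 4.0-fold higher number from compound 2 to compound 3 (0.60 log units; beyond the scatter) is a step beyond the scatter, with 4-methoxyphenyl in place of 3-nitrophenyl. With 3-chlorophenyl as the group replaced, a 2.0-fold higher number from compound 1 to compound 3 (0.30 log units; within the scatter) stays within the scatter, so the size of the step depends on which group leaves. Nothing available explains this difference.

Compound 3 differs from compounds 1 and 2 in both the substituent and its place on the ring, so these two changes cannot be told apart. Going by these compounds, whether an amine or a carboxylic acid on this ring would give lower numbers remains open.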